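The source may report more compounds than this note shows. Statements on the series, on what has been measured and on what is new or still open speak of the compounds shown alone.

Measured so far in a functional assay on NCI-H1975 cells (Homo sapiens) for antiproliferative activity, read by MTT assay, with a stated time of 72 h; on this read-out higher numbers stand for weaker inhibition and lower numbers for stronger inhibition:
- compound 1 `C=CC(=O)Nc1cc2c(Nc3cccc(Cl)c3F)ncnc2cc1OCc1cn(CCCCC(=O)NO)nn1`: 4180 nM
- compound 2 `C=CC(=O)Nc1cc2c(Nc3ccc(F)c(Cl)c3)ncnc2cc1OCc1cn(CCCC(=O)NO)nn1`: 1820 nM

Compound 2 has the lower number of the two, and its gap to compound 1 lies beyond the scatter. These two differ in more than one place, so the gap isolates no single change. Compound 3 `C=CC(=O)Nc1cc2c(Nc3ccc(F)c(Cl)c3)ncnc2cc1OCc1cn(CCCCC(=O)NO)nn1` differs from compound 2 in one place: (hydroxycarbamoyl)methyl in place of hydroxycarbamoyl on a saturated chain carbon, three bonds along the chain from an aromatic nitrogen. A modest rise in this assay is expected because compound 1, with the same 4-(hydroxycarbamoyl)butyl chain, gives 4180 nM. The estimated step is a 1.4-fold higher number from compound 2 to compound 3 (0.14 log units; within the scatter). For compound 3 the estimate is 2500 nM, with an expected range of 900 nM to 6000 nM.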

Compound 3, half-maximal inhibitory concentration: 2500 nM
Estimate against measurement, compound 3: no gap at the digits printed, within the range that was stated.
By their numbers in this assay, from the lowest: compounds 2, 3 and 1 (each within the scatter of the next, the first and the last beyond it).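

In this assay, going from the 3-(hydroxycarbamoyl)propyl chain to the 4-(hydroxycarbamoyl)butyl chain gives a 1.4-fold higher number from compound 2 to compound 3 (0.14 log units; within the scatter) so this read-out does not tell these two chain lengths apart. With the chain held constant, 3-chloro-4-fluorophenyl in place of 3-chloro-2-fluorophenyl gives a 1.7-fold lower number from compound 1 to compound 3 (0.22 log units; within the scatter) so the aryl change alone also stays within the scatter, a separation that the pair of compound 1 and compound 2 could not provide. No measured evidence bears on the reason for either step.

From the compounds shown here alone, a longer chain remains open, as does a carboxylic acid in place of the hydroxycarbamoyl group at the chain end.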